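Cyclopropyl replacing isopropyl at the chain carbon of compound 2

This account rests on a few compounds, and the source may have more. Where it says the series, first, only, none or still open, it means among the compounds named here.

Going by the values given here, compound 2 `CC(C)c1coc([C@H](Nc2c(Nc3cccc(C(=O)N(C)C)c3O)c(=O)c2=O)C(C)C)c1` stands at the higher end of the two numbers so far in an assay on CHO cells for displacement of a labelled ligand from C-X-C chemokine receptor type 1 (Homo sapiens) (on this read-out lower numbers stand for stronger inhibition and higher numbers for weaker inhibition), where compound 2 gives 11 nM. Its nearest neighbour, compound 1 `CC[C@@H](Nc1c(Nc2cccc(C(=O)N(C)C)c2O)c(=O)c1=O)c1cc(C(C)C)co1`, gives 3 nM in this assay; the step of a 3.7-fold higher number from compound 1 to compound 2 (0.56 log units; beyond the scatter) is the only one measured at this chain carbon and shows that a change there is felt. Compound 3 `CC(C)c1coc([C@H](Nc2c(Nc3cccc(C(=O)N(C)C)c3O)c(=O)c2=O)C2CC2)c1` differs from compound 2 by cyclopropyl in place of isopropyl on a saturated chain carbon bound to an aromatic carbon and a nitrogen on an aromatic ring. Among the compounds with values here, no measured step covers an isopropyl-to-cyclopropyl exchange, so the only guide is that the measured change at this position was modest and that cyclopropyl returns the carbon count of the group while closing it into a ring. A step no larger than the measured one, and possibly within the scatter, is therefore expected in this assay for compound 3, direction uncertain but leaning toward a lower number. Compound 3 is estimated at 7 nM, range 3 nM to 18 nM. The expected step is a 1.6-fold lower number from compound 2 to compound 3 (0.20 log units; within the scatter).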

Compound 3, inhibition constant: 10 nM
The estimate for compound 3 lay 1.4-fold (0.15 log units) below the measured number; the measured number falls inside the stated range.
By their numbers in this assay, from the lowest: compound 1; then compounds 3 and 2 (each within the scatter of the next).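

In this assay, isopropyl and cyclopropyl on the saturated chain carbon bound to an aromatic carbon and a nitrogen on an aromatic ring cannot be told apart, with a 1.1-fold lower number from compound 2 to compound 3 (0.04 log units; within the scatter) as the step. Ethyl now stands apart from both groups, since cyclopropyl in its place gives a 3.3-fold higher number from compound 1 to compound 3 (0.52 log units; beyond the scatter) and this step lies beyond the scatter, as does a 3.7-fold higher number from compound 1 to compound 2 (0.56 log units; beyond the scatter) for isopropyl. No measurement at hand explains these steps.

Among the three groups, ethyl gives the lowest number, but whether methyl, a longer chain such as n-propyl or a larger ring such as cyclobutyl would match it remains open. Also open, on these data alone, is how a methoxymethyl group would fare at this carbon.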